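The source may hold more compounds than are shown below. What is called first, only, known or untested is meant among the compounds shown, and "the series" means these compounds.

Measured so far:
compound 1 `CCOC(=O)c1c(-c2cccc(C(F)(F)F)c2)csc1N` — 93%
compound 2 `Nc1sc(-c2ccc(Cl)cc2)c(-c2cccc(C(F)(F)F)c2)c1C(=O)c1ccccc1` — 59.1%

Compound 1 stands highest of the two numbers in an assay on CHO-K1 cells for displacement of a labelled ligand from adenosine receptor A1 (Homo sapiens), tested at 10 uM; a lower number here means less inhibition, a higher number more inhibition at the concentration tested (going by the name of the read-out); its nearest neighbour is compound 2, whose value lies lower by a gap beyond the scatter. Among the measured compounds shown here, no step between the two is counted, since compound 2 differs from compound 1 in more than one place; the two values only show that the compound carrying an aryl group on the ring carbon beside the sulfur, together with a different carbonyl substituent, gives the lower inhibition.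

Compound 3 `CCOC(=O)c1c(N)sc(-c2ccc(C(C)=O)cc2)c1-c1cccc(C(F)(F)F)c1` has not yet been measured. It differs from compound 1 by 4-acetylphenyl in place of hydrogen on an aromatic carbon. For the measured compounds named here, the only available comparison, compound 2 with 59.1% against compound 1 with 93%, points toward a lower number once an aryl group occupies that position, but that comparison is confounded by the second difference.

On that basis the step from compound 1 to compound 3 is expected to be a moderate decrease, a number 23 percentage points lower from compound 1 to compound 3 (beyond the scatter), beyond the scatter. For compound 3 the expected inhibition in this assay is estimated at 70%, in a range from 45% to 92%.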

Compound 3, a percentage reported as inhibition, at one concentration (the size of the read-out at that concentration, not a potency): 64.6%
For compound 3 the middle estimate is 5.4 percentage points above the measured one; low and high end bracket the measured number.
By their numbers in this assay, from the lowest: compounds 2 and 3 (each within the scatter of the next); then compound 1.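

In this assay, among the compounds shown here, hydrogen giving way to 4-acetylphenyl on the aromatic carbon next to the ring sulfur gives a number 28.4 percentage points lower from compound 1 to compound 3 (beyond the scatter) and provides the first reading of this position with the ethoxycarbonyl group unchanged. The drop can therefore be assigned to this single change, without the second difference that accompanies the aryl group in compound 2, and the substituted compound 3 still retains 64.6% of inhibition at the concentration tested. No measurement available here accounts for the size of this step.

The compounds shown leave open whether the step comes from the phenyl ring itself or from its acetyl group, a question that an unsubstituted phenyl or a small methyl group at this position would help to settle. Also open, going by these compounds, is how the read-out responds when the acetyl group on the phenyl ring is replaced by a carboxylic acid or an amine, and whether a longer chain between that ring and the core of compound 1 changes the picture.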